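Three amine-bearing analogues and an untested hydroxypiperidine

The source may report more compounds than this note shows. Statements on the series, on what has been measured and on what is new or still open speak of the compounds shown alone.

Compound 1 `CN1CCN(CCCCCCn2c3c(c4ccccc42)C(=O)c2c[n+]([O-])c4ccccc4c2C3=O)CC1`: 400 nM
Compound 2 `CN1CCN(CCCCCn2c3c(c4ccccc42)C(=O)c2c[n+]([O-])c4ccccc4c2C3=O)CC1`: 1260 nM
Compound 3 `O=C1c2c[n+]([O-])c3ccccc3c2C(=O)c2c1c1ccccc1n2CCN1CCCC1`: 320 nM

Among the compounds with values here, in a functional assay on MCF7 cells (Homo sapiens) for cytotoxicity, read by MTT assay, with a stated time of 72 h (on this read-out higher numbers stand for weaker inhibition and lower numbers for stronger inhibition), compound 3 gives the lowest of the three numbers, though it sits within the scatter of compound 1, and a 3.9-fold lower number from compound 2 to compound 3 (0.60 log units; beyond the scatter) is the only step that sets it apart. Compound 4 `O=C1c2c[n+]([O-])c3ccccc3c2C(=O)c2c1c1ccccc1n2CCCN1CCC(O)CC1` has not been measured; it differs from compound 3 by (4-hydroxypiperidin-1-yl)methyl in place of pyrrolidin-1-yl on a saturated chain carbon, two bonds along the chain from an aromatic nitrogen. Within the data shown here, no measured step swaps one amine ring for another, so the closest guide is a 3.2-fold higher number from compound 1 to compound 2 (0.50 log units; beyond the scatter), where the chain to the amine was altered, together with a 1.3-fold lower number from compound 1 to compound 3 (0.10 log units; within the scatter), where a large change at the same place left the number within the scatter. She therefore expects compound 4 to stay near compound 3, with a 1.1-fold higher number from compound 3 to compound 4 (0.04 log units; within the scatter) as the estimated step, and estimates compound 4 at 350 nM with a range of 150 nM to 900 nM.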

Compound 4, half-maximal inhibitory concentration: 190 nM
For compound 4 the middle estimate is 1.8-fold (0.27 log units) above the measured one; low and high end bracket the measured number.
By their numbers in this assay, from the lowest: compounds 4, 3 and 1 (each within the scatter of the next, the first and the last beyond it); then compound 2.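

In this assay the 3-(4-hydroxypiperidin-1-yl)propyl group stands in for 2-(pyrrolidin-1-yl)ethyl with a 1.7-fold lower number from compound 3 to compound 4 (0.23 log units; within the scatter) and no change that can be told from scatter. The 4-hydroxypiperidin-1-yl compound does separate from the 4-methylpiperazin-1-yl compounds, with a 2.1-fold lower number from compound 1 to compound 4 (0.32 log units; beyond the scatter) and with a 6.6-fold lower number from compound 2 to compound 4 (0.82 log units; beyond the scatter) as the larger step. No evidence is available that explains these steps.

Ring and chain length change together in each of these steps, so their separate shares remain unknown. A 3-(pyrrolidin-1-yl)propyl or 2-(4-hydroxypiperidin-1-yl)ethyl group would divide them, and a morpholine ring would test the hydroxyl-bearing ring further.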